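A few compounds are considered here, and "the series" means these few. Any claim that something is new, unique, unknown or untested is made for them only; others in the source may bear on it.

Measured so far, each entry a limit of the assay and not a number:
Compound 1 `CC(=O)N[C@@H](CSC(=O)Nc1ccccc1Cl)C(=O)O`: > 200000 nM
Compound 2 `COc1ccc(NC(=O)SC[C@H](NC(C)=O)C(=O)O)cc1`: > 200000 nM
Compound 3 `CC(=O)N[C@@H](CSC(=O)Nc1ccc(Br)cc1)C(=O)O`: > 200000 nM

In a functional assay on OVCAR-3 cells (Homo sapiens) for cytotoxicity, read by MTT assay, with a stated time of 6 days (on this read-out lower numbers stand for stronger inhibition and higher numbers for weaker inhibition), compound 1 gives > 200000 nM, which is a limit and not a number. It has no better placing than that: the limit of > 200000 nM in this assay, at which 3 of the 3 values shown sit.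

Compound 4 `CC(=O)N[C@@H](CSC(=O)Nc1ccccc1)C(=O)O` has not yet been measured. It differs from compound 1 by hydrogen in place of chloro on an aromatic carbon, which is hydrogen in place of chloro on an aromatic carbon, ortho to a large group. For the measured compounds named here, the one measured step that bears on this also changes a group on an aromatic carbon: a step that the two limits leave unreadable from compound 2 to compound 3. It therefore gives no size to carry over, and no change beyond the usual scatter is expected in this assay. The expected change is a number no higher from compound 1 to compound 4 (the limit leaves the size open). For compound 4 the estimated value is 200000 nM, with an expected range from 100000 nM to 400000 nM.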

Compound 4, half-maximal inhibitory concentration: 153000 nM
Beside the measured number, compound 4's estimate is 1.3-fold (0.12 log units) above it; the range from low to high includes it.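

In this assay, compound 4, with hydrogen on this aromatic carbon, is the only compound shown that gives a number rather than a limit. Replacing the chloro with hydrogen gives an at least 1.3-fold lower number from compound 1 to compound 4 (0.11 log units; that floor lies within the scatter), and replacing the other two aromatic groups with hydrogen gives an at least 1.3-fold lower number from compound 3 to compound 4 (0.11 log units; that floor lies within the scatter) and an at least 1.3-fold lower number from compound 2 to compound 4 (0.11 log units; that floor lies within the scatter). No step is shown to exceed the scatter, and the true sizes stay open because the other values are limits: the limit of > 200000 nM in this assay, at which 3 of the 4 values shown sit.

From the compounds shown here alone, whether an amine or a nitrile on this aromatic carbon would give a clearly lower number in this assay remains open.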